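Swapping the aryl group on a shared kinase-binding core

The compounds below may be only part of what the source reports. "The series", "measured", "known", "first", "only" and "open" are said of these compounds alone.

Compound 3 `CCCS(=O)(=O)Nc1ccc(F)c(C(=O)c2n[nH]c3ncc(-c4ccccc4N)cc23)c1F`: 23%
Compound 2 `CCCS(=O)(=O)Nc1ccc(F)c(C(=O)c2n[nH]c3ncc(-c4cccc(OC)c4)cc23)c1F`: 6.3%
Compound 1 `CCCS(=O)(=O)Nc1ccc(F)c(C(=O)c2n[nH]c3ncc(-c4cccc(Cl)c4)cc23)c1F`: 40%

In an assay for binding affinity to dual specificity mitogen-activated protein kinase kinase 4 (Homo sapiens), read by KINOMEscan, tested at 100 nM (a lower number here means a stronger effect, a higher number a weaker effect of the compound at the concentration tested), compound 3 gives 23%, the second highest of the three numbers; compound 2 lies a number 16.7 percentage points higher from compound 2 to compound 3 (beyond the scatter) away on one side, and compound 1 lies a number 17 percentage points lower from compound 1 to compound 3 (beyond the scatter) away on the other. Compound 4 `CCCS(=O)(=O)Nc1ccc(F)c(C(=O)c2n[nH]c3ncc(-c4ccc(C(C)C)cc4)cc23)c1F` differs from compound 3 only in the aryl group: 4-isopropylphenyl in place of 2-aminophenyl on an aromatic carbon. Among the measured compounds shown here, no measured step covers this particular exchange. The closest guides are the aryl swaps already seen, a number 33.7 percentage points lower from compound 1 to compound 2 (beyond the scatter) and a number 17 percentage points lower from compound 1 to compound 3 (beyond the scatter), which show that changing this group can move the read-out well beyond the scatter in either direction. With no donor or acceptor entering, a modest rise is expected, a number 12 percentage points higher from compound 3 to compound 4 (beyond the scatter). Compound 4 is therefore estimated at 35%, within a range from 10% to 70%.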

Compound 4, a percentage reported as activity, at one concentration (the size of the read-out at that concentration, not a potency): 17%
The estimate for compound 4 lay 18 percentage points above the measured number; measured number inside the range.
By their numbers in this assay, from the lowest: compound 2; then compounds 4 and 3 (each within the scatter of the next); then compound 1.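

In this assay, 4-isopropylphenyl, with no hydrogen-bond donor or acceptor, matches 2-aminophenyl at this position, a number 6 percentage points lower from compound 3 to compound 4 (within the scatter), so the donor and acceptor of compound 3 are not required for a read-out at this level. The same group still separates from the other two aryl groups, a number 23 percentage points lower from compound 1 to compound 4 (beyond the scatter) and a number 10.7 percentage points higher from compound 2 to compound 4 (beyond the scatter), placing compound 4 on the stronger side of the 3-chlorophenyl compound and the weaker side of the 3-methoxyphenyl compound. No evidence is available to explain these differences.

Going by these compounds, it remains open whether 4-methoxyphenyl would match 3-methoxyphenyl, and how a carboxylic acid on this phenyl ring would change the read-out.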